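The source may report more compounds than this note shows. Statements on the series, on what has been measured and on what is new or still open speak of the compounds shown alone.

Measured compounds in this series:

Compound 1 `COc1cc2c(cc1C)NC(=O)/C2=C/c1c(Cl)n(C)c2cc(C)c(OC)cc12` – 18200 nM
Compound 2 `COc1cc2c(cc1C)N(C)C(=O)/C2=C/c1c(Cl)n(C)c2cc(C)c(OC)cc12` – 6920 nM
Compound 3 `CN(C)c1ccc2[nH]c(Cl)c(/C=C3/C(=O)Nc4ccc(O)cc43)c2c1` – 2240 nM

All three were tested in a functional assay on cells (Leukemia cell, Homo sapiens) for inhibition, with a stated time of 48 h; a lower number here means a stronger inhibitor of growth, a higher number a weaker inhibitor of growth. In this assay compound 1 gives 18200 nM, compound 2 gives 6920 nM and compound 3 gives 2240 nM. Compound 3 has the lowest number of the three, and its distance to compound 2 and to compound 1 is in each case beyond the scatter.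

Compounds 1 and 2 share one core and differ in one place, (methyl in place of hydrogen on an amide-type nitrogen in a ring). That step, a 2.6-fold lower number from compound 1 to compound 2 (0.42 log units; beyond the scatter), is a modest lowering. Compound 3 sits on a different core; the difference between the two cores is not broken down here, so the two values are compared only as they stand.

Compound 4 `CN(C)c1ccc2[nH]c(Cl)c(/C=C3/C(=O)N(C)c4ccc(O)cc43)c2c1` is not yet measured. It differs from compound 3 by methyl in place of hydrogen on an amide-type nitrogen in a ring, the same change as that from compound 1 to compound 2: the two descriptions of the place agree word for word.

Expectation for compound 4 in this assay: the number is expected to fall by about a 2.2-fold lower number from compound 3 to compound 4 (0.35 log units; beyond the scatter), beside the earlier step of a 2.6-fold lower number from compound 1 to compound 2 (0.42 log units; beyond the scatter), because a 2.6-fold lower number from compound 1 to compound 2 (0.42 log units; beyond the scatter) is the only measured instance of this change and it lowered the number modestly. The step is carried over with some caution, since the core of compound 3 is not the core of compound 1. The estimated value for compound 4 is 1000 nM, with an expected range from 400 nM to 3000 nM.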

Compound 4, concentration for 50% growth inhibition: 16600 nM
Compound 4: the middle estimate sits 17-fold (1.22 log units) below what was measured; the measured number lies above the stated range.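

In this assay, methyl in place of hydrogen on an amide-type nitrogen in a ring gives a 7.4-fold higher number from compound 3 to compound 4 (0.87 log units; beyond the scatter), so on this core the change raises the number, whereas on the core of compound 1 it lowers it. The change therefore does not carry over from one core to the other in this series, either in direction or in size: the same change on two cores in this assay, a 2.6-fold lower number (0.42 log units; beyond the scatter) from compound 1 to compound 2 and a 7.4-fold higher number (0.87 log units; beyond the scatter) from compound 3 to compound 4, 19-fold (1.29 log units) apart, beyond the scatter of two such steps This does not show which feature of the two cores separates the outcomes, and with a single pair on each core it gives no rule for either core or for any other core in the series.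

Open, as far as these compounds go, is whether a longer chain such as ethyl, or a chain ending in an amine or a carboxylic acid, on the same nitrogen would follow the step to compound 2 or the step to compound 4. Also open, from the compounds shown here alone, is which of the groups that differ between the two cores decides the direction of the step; a compound carrying only some of those groups, with and without the methyl, would bear on this.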